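Swapping the Aryl Group on the Shared Core for Isopropyl

A few compounds are considered here, and "the series" means these few. Any claim that something is new, unique, unknown or untested is made for them only; others in the source may bear on it.

All numbers come from a functional assay on PC-3 cells (Homo sapiens) for cytotoxicity, read by MTT assay, with a stated time of 72 h; a higher number here means a weaker inhibitor, a lower number a stronger inhibitor.
- Compound 1 `Cc1ccc(Nc2cc(C)nc(SCc3nc4ccccc4[nH]3)n2)cc1` gives 56000 nM.
- Compound 2 `Cc1cc(N2CCNCC2)nc(SCc2nc3ccccc3[nH]2)n1` gives only a limit of the assay, > 100000 nM.
- Compound 3 `COc1ccccc1Nc1cc(C)nc(SCc2nc3ccccc3[nH]2)n1` gives 70800 nM.

Among the two compounds with a number, compound 3 stands highest, but its nearest neighbour is compound 1, and the step of a 1.3-fold higher number from compound 1 to compound 3 (0.10 log units; within the scatter) lies within the scatter, so the two cannot be told apart. Compound 2 sits at the limit of > 100000 nM in this assay, at which 1 of the 3 values shown sits.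

Compound 4 `Cc1cc(NC(C)C)nc(SCc2nc3ccccc3[nH]2)n1` has not been measured. It differs from compound 3 by isopropyl in place of 2-methoxyphenyl on a nitrogen on an aromatic ring. Within the data shown here, two measured steps bear on this change. The step of a 1.3-fold higher number from compound 1 to compound 3 (0.10 log units; within the scatter) exchanges one aromatic group for another on the same nitrogen and stays within the scatter. The step of an at least 1.4-fold lower number from compound 2 to compound 3 (0.14 log units; that floor lies within the scatter) replaces a piperazin-1-yl group with an arylamino group and has a floor that also lies within the scatter. Neither step tests an isopropyl group, so no direction beyond the scatter is expected for a 1.1-fold higher number from compound 3 to compound 4 (0.05 log units; within the scatter).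

Compound 4 is therefore estimated at 80000 nM, with a range from 35000 nM to 200000 nM.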

Compound 4, half-maximal inhibitory concentration: > 100000 nM
Compound 4: a limit, no number (the forecaster's own chance of this, stated with the estimate: 30%); middle value at least 1.2-fold (0.09 log units) from the limit.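

Among these compounds, compound 4 is the first compound here with an open-chain group on this nitrogen, and in this assay it gives only a limit of the assay, not a number. Against the two compounds that keep an aromatic ring in this group, the change to isopropyl gives an at least 1.4-fold higher number from compound 3 to compound 4 (0.14 log units; that floor lies within the scatter) and an at least 1.7-fold higher number from compound 1 to compound 4 (0.25 log units; that floor lies within the scatter), so each step is only a floor that does not by itself separate the compounds. The step to compound 2 cannot be read, and among the compounds shown only those with an aromatic ring in this group, compound 1 and compound 3, give numbers, while the two without one reach the same limit: the limit of > 100000 nM in this assay, at which 2 of the 4 values shown sit.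

From the compounds shown here alone, it remains open whether the aromatic ring itself matters, or whether another group on this nitrogen could also give a number, such as a cyclohexyl group, a benzyl group or a longer chain. Aromatic rings with other substituents, such as a fluorine atom or a carboxylic acid, would also show how far numbers in this assay can move from those of compound 1 and compound 3.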